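Hydrogen for methyl on an aromatic nitrogen: cytotoxicity notes

The source may report more compounds than this note shows. Statements on the series, on what has been measured and on what is new or still open speak of the compounds shown alone.

Compound 1 `Cn1c(/C=C/C(=O)c2ccccc2)cc(Br)c1Br` and compound 2 `O=C(/C=C/c1cc(Br)c(Br)[nH]1)c1ccccc1` share one core and differ only by hydrogen in place of methyl on an aromatic nitrogen. In a functional assay on Caco-2 cells (Homo sapiens) for cytotoxicity, read by MTT assay, with stated times of 6 h and 48 h (on this read-out higher numbers stand for weaker inhibition and lower numbers for stronger inhibition), compound 1 gives no number, only a limit, >= 100000 nM. Compound 2 likewise returns a limit in this assay, >= 100000 nM. The step that the two limits leave unreadable from compound 1 to compound 2 is therefore not readable, since both values sit at the limit of >= 100000 nM in this assay, at which 3 of the 3 values shown sit.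

Compound 3 `Cn1c(-c2cc(-c3ccc[nH]3)no2)cc(Br)c1Br` carries a different core; the difference between the two cores is not broken down here. In this assay compound 3 also gives only a limit, >= 100000 nM.

Compound 4 `Brc1cc(-c2cc(-c3ccc[nH]3)no2)[nH]c1Br` has not been measured. It differs from compound 3 by hydrogen in place of methyl on an aromatic nitrogen, the same change, at the same place, as that from compound 1 to compound 2.

Compound 4 is expected to return a limit rather than a number, with an estimate of 100000 nM and a range from 50000 nM to 300000 nM. The implied step a number no higher from compound 3 to compound 4 (the limit leaves the size open) is expected to be flat because a step that the two limits leave unreadable from compound 1 to compound 2 could not be read and every value shown in this assay rests at the limit of >= 100000 nM in this assay, at which 3 of the 3 values shown sit.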

Compound 4, half-maximal inhibitory concentration: >= 100000 nM
Compound 4 gave a limit, no number (the forecaster's own chance of this, stated with the estimate: 90%); the middle value sits exactly at the limit.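

In this assay, compound 3 and compound 4 each stand only as a limit, so no new step can be read between them: the limit of >= 100000 nM in this assay, at which 4 of the 4 values shown sit.

The compounds shown leave open how large any effect of hydrogen in place of methyl on an aromatic nitrogen is in this assay, as none of them gives a number.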